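Bromo for Chloro in a Small Halogen Series

The source may report more compounds than this note shows. Statements on the series, on what has been measured and on what is new or still open speak of the compounds shown alone.

Three compounds with a shared core were tested in a functional assay on HepG2 cells (Homo sapiens) for antiproliferative activity, read by MTT assay, with a stated time of 48 h (a lower number here means a stronger inhibitor, a higher number a weaker inhibitor), and all gave numbers. In this assay compound 1 (`O=[N+]([O-])c1cc(C(F)(F)F)cc([N+](=O)[O-])c1Oc1ccccc1/C=N\OCc1ccccc1F`) gives 680 nM and compound 2 (`O=[N+]([O-])c1cc(C(F)(F)F)cc([N+](=O)[O-])c1Oc1ccc(Cl)cc1/C=N\OCc1ccccc1F`) gives 1020 nM while compound 3 (`O=[N+]([O-])c1cc(C(F)(F)F)cc([N+](=O)[O-])c1Oc1ccc(Cl)cc1/C=N\OCc1ccccc1Cl`) gives 1510 nM as its reading. Compound 2 therefore stands within the usual scatter of both other compounds, so its number cannot be ranked against either of them.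

Compound 4 (`O=[N+]([O-])c1cc(C(F)(F)F)cc([N+](=O)[O-])c1Oc1ccc(Br)cc1/C=N\OCc1ccccc1F`) has not been measured yet. The change from compound 2 to compound 4 is bromo in place of chloro on an aromatic carbon and amounts to bromo in place of chloro on an aromatic carbon. Among the measured compounds shown here, no measured compound carries a bromo, so this swap has no direct precedent here. The nearest guides are the arrival of chloro at this same place in a 1.5-fold higher number from compound 1 to compound 2 (0.18 log units; within the scatter) and the exchange of one halogen for another elsewhere in the molecule in a 1.5-fold higher number from compound 2 to compound 3 (0.17 log units; within the scatter) and both steps stay within the scatter. The expected step is thus a 1.1-fold higher number from compound 2 to compound 4 (0.03 log units; within the scatter) and no change beyond the scatter is expected in either direction. For compound 4 the estimated value is 1100 nM with an expected range from 600 nM up to 2000 nM as its likely span.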

Compound 4, half-maximal inhibitory concentration: 890 nM
Beside the measured number, compound 4's estimate is 1.2-fold (0.09 log units) above it, within the range that was stated.
By their numbers in this assay, from the lowest: compounds 1, 4, 2 and 3 (each within the scatter of the next, the first and the last beyond it).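

In this assay, bromo in place of chloro on this aromatic carbon gives a 1.1-fold lower number from compound 2 to compound 4 (0.06 log units; within the scatter) and so stays within the usual scatter, which means that exchanging one halogen for another at this place leaves no readable mark on the number. Compared directly with hydrogen at the same carbon, bromo gives a 1.3-fold higher number from compound 1 to compound 4 (0.12 log units; within the scatter) and also stays within the scatter, just as chloro did with a 1.5-fold higher number from compound 1 to compound 2 (0.18 log units; within the scatter) in the earlier step, so neither of these two halogens has yet been seen to separate from hydrogen here. Nothing available explains why these numbers lie so close together.

The compounds shown carry only hydrogen, chloro and bromo at this place, so it remains open whether an amine, a carboxylic acid or a longer chain on this carbon would move the number beyond the scatter. As far as these compounds go, it also remains open how bromo at this place would read in the setting of compound 3, where chloro stands in place of fluoro on the benzyl-side aromatic ring.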